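The compounds below may be only part of what the source reports. "The series", "measured", "known", "first", "only" and "open" are said of these compounds alone.

Measured so far in a functional assay on Caco-2 cells (Homo sapiens) for inhibition, read by MTT assay, with a stated time of 48 h, tested at 10 uM; on this read-out higher numbers stand for more inhibition of growth at the one concentration tested and lower numbers for less inhibition of growth:

Compound 1 `COc1ccc(COc2cc(O)c3c(=O)cc(C)oc3c2[C@H]2CCN(C)C[C@H]2O)cc1` gives 8%
Compound 2 `Cc1cc(=O)c2c(O)c(CN3CCC(N4CCCCC4)CC3)c(O)c([C@H]3CCN(C)C[C@H]3O)c2o1` gives 31%
Compound 3 `Cc1cc(=O)c2c(O)c(CN(C)CC(=O)O)c(O)c([C@H]3CCN(C)C[C@H]3O)c2o1` gives 18%

The value of compound 3 (18%) lies within the usual scatter of the value of compound 1 (8%), so this assay does not separate the two. Compound 2 (31%) stands above compound 3 by more than the scatter.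

Compound 4 `Cc1cc(=O)c2c(O)c(CN3CCCC3C(=O)O)c(O)c([C@H]3CCN(C)C[C@H]3O)c2o1` has not yet been measured. It carries 2-carboxypyrrolidin-1-yl in place of (carboxymethyl)(methyl)amino on a saturated chain carbon bound to an aromatic carbon. The carboxy function stays, and a five-membered ring enters.

Among the measured compounds shown here, no two measured compounds differ in just one place, so the data give no direct guide to the effect of this swap. With so small a change, no shift beyond the scatter is expected in this assay. The expected change is no change at the digits printed from compound 3 to compound 4 (within the scatter). The estimated value for compound 4 is 18%, with an expected range from 6% to 32%.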

Compound 4, percent growth inhibition at one concentration: 30%
Compound 4: middle estimate off by 12 percentage points, on the low side, within the range that was stated.
By their numbers in this assay, from the lowest: compounds 1 and 3 (each within the scatter of the next); then compounds 4 and 2 (each within the scatter of the next).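

In this assay, 2-carboxypyrrolidin-1-yl in place of (carboxymethyl)(methyl)amino on a saturated chain carbon bound to an aromatic carbon gives a number 12 percentage points higher from compound 3 to compound 4 (beyond the scatter). Among the compounds shown here, this is the first pair of compounds here that differ in one place, and it shows that the read-out can respond to the group at this position even when the carboxy function stays. Nothing measured here gives a reason for the step.

The ring and the extra atoms enter together, so the compounds shown leave open whether the ring itself matters or its size. A 2-carboxypiperidin-1-yl group, with its six-membered ring, or the methyl ester in place of the carboxylic acid on the pyrrolidine would help to separate these questions.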